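Swapping pyrrolyl for fluoro on an isomerase inhibitor

The source may report more compounds than this note shows. Statements on the series, on what has been measured and on what is new or still open speak of the compounds shown alone.

Measured so far:
- compound 1 `Cc1ccnc(NC(c2ccc(C(F)(F)F)cc2)c2ccc3cccnc3c2O)c1`: 26500 nM
- compound 2 `Oc1ccc2[nH]ncc2c1C(c1ccc(-n2cccc2)cc1)N1CCCCC1`: 290 nM
- compound 3 `Oc1ccc2[nH]ccc2c1C(c1ccc(F)cc1)N1CCCCC1`: 1810 nM

In an assay for inhibition of protein disulfide-isomerase (Homo sapiens), with a stated time of 1 h (on this read-out lower numbers stand for stronger inhibition and higher numbers for weaker inhibition), compound 2 gives the lowest number of the three, with 290 nM. Its nearest neighbour on this read-out is compound 3 at 1810 nM, a gap beyond the scatter, and compound 1 lies much further away at 26500 nM.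

Compound 4 `Oc1ccc2[nH]ncc2c1C(c1ccc(F)cc1)N1CCCCC1` has not yet been measured. Compared with compound 2, the change is fluoro in place of 1H-pyrrol-1-yl on an aromatic carbon. Among the compounds with values here, no directly comparable pair of measured compounds shows what this single change does, so the step is uncertain. Compound 3, which also carries fluoro on that ring but a different core, stands at 1810 nM, weaker than compound 2.

Compound 4 is expected to come in around 1500 nM, with a plausible range from 400 nM to 5000 nM. That would mean an expected step of a 5.2-fold higher number from compound 2 to compound 4 (0.71 log units; beyond the scatter), a loss of potency beyond the scatter.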

Compound 4, half-maximal inhibitory concentration: 350 nM
Beside the measured number, compound 4's estimate is 4.3-fold (0.63 log units) above it, and the stated range ends above it.
By their numbers in this assay, from the lowest: compounds 2 and 4 (each within the scatter of the next); then compound 3; then compound 1.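

Replacing 1H-pyrrol-1-yl with fluoro gives a 1.2-fold higher number from compound 2 to compound 4 (0.08 log units; within the scatter) in this assay, so on this core the five-membered aromatic ring can go from this aromatic carbon, para to a large group, with no change that can be told from the scatter. The earlier compounds shown here could not show this, as none of them formed a pair differing only at this place. Nothing measured here explains why the two groups read alike.

From the compounds shown here alone, what remains open is whether this position accepts almost any group or only some, since just these two are seen on the shared core. An amine, a carboxylic acid, a longer chain or plain hydrogen on this carbon would test how far that tolerance extends.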